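Replacing a Carboxyphenyl Group with a Fluoropyridine Ring

The compounds below may be only part of what the source reports. "The series", "measured", "known", "first", "only" and "open" are said of these compounds alone.

This account concerns a pair of measured analogues and one compound awaiting measurement in an in vitro assay on CHO cells for displacement of a labelled ligand from Bombesin receptor subtype-3 (Homo sapiens), read by scintillation counting, with a stated time of 2 h; on this read-out higher numbers stand for weaker inhibition and lower numbers for stronger inhibition. Compound 1, `CCC(C)(C)Cc1c[nH]c(CCc2ccc(-n3cccn3)cc2)n1`, carries a pyrazol-1-yl group and in this assay gives 33 nM. Compound 2, `CCC(C)(C)Cc1c[nH]c(CCc2ccc(-c3ccccc3C(=O)O)cc2)n1`, differs in a single place and gives 11 nM, the lowest of the two numbers recorded; its nearest neighbour is compound 1, and the step of a 3.0-fold lower number from compound 1 to compound 2 (0.48 log units; beyond the scatter) lies beyond the usual scatter.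

Compound 3, `CCC(C)(C)Cc1c[nH]c(CCc2ccc(-c3ccc(F)cn3)cc2)n1`, is the unmeasured member. Its change from compound 2 is 5-fluoropyridin-2-yl in place of 2-carboxyphenyl on an aromatic carbon, at a position para to a large group. Going by the values given here, the one measured step that bears on it, a 3.0-fold lower number from compound 1 to compound 2 (0.48 log units; beyond the scatter), shows that exchanging one aromatic group for another at this position can move the number modestly, yet no measured pair tests the fluoropyridine itself. The author therefore expects a modest step back toward the figure of compound 1, which is a 2.3-fold higher number from compound 2 to compound 3 (0.36 log units; beyond the scatter). Compound 3 is estimated at 25 nM, with a range from 8 nM to 80 nM.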

Compound 3, half-maximal inhibitory concentration: 19 nM
Compound 3: the middle estimate sits 1.3-fold (0.12 log units) above what was measured, within the range that was stated.
By their numbers in this assay, from the lowest: compounds 2, 3 and 1 (each within the scatter of the next, the first and the last beyond it).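

In this assay, the exchange of 2-carboxyphenyl for 5-fluoropyridin-2-yl gives a 1.7-fold higher number from compound 2 to compound 3 (0.24 log units; within the scatter), so this position on the six-membered aromatic ring of carbon only accepts a group with 0 hydrogen-bond donors, a ring hetero atom and a fluorine, with no change that can be told from the scatter. The exchange of 1H-pyrazol-1-yl for the same group gives a 1.7-fold lower number from compound 1 to compound 3 (0.24 log units; within the scatter), also within the scatter, so compound 3 cannot be separated from either neighbour, even though the step between those two neighbours lies beyond it; the earlier pair alone had suggested a clearer separation among aromatic groups at this place. No measurement is at hand that explains why these three groups give such close numbers.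

The compounds shown leave open what the fluorine itself contributes, a question that a plain pyridin-2-yl group, or a nitrile or a primary amide on the pyridine ring in its stead, would address. They also leave open whether a saturated ring, such as a piperidine, or an amine would be accepted at this position as the aromatic groups are.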